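Swapping the urea aryl for an ester-bearing chain

The source may report more compounds than this note shows. Statements on the series, on what has been measured and on what is new or still open speak of the compounds shown alone.

This account concerns a series of ureas built on a shared core and tested in a functional assay on HEK293 cells for agonist activity at Vasopressin V2 receptor (Homo sapiens), read by a luciferase reporter and cAMP accumulation; a lower number here means that less compound is needed, a higher number that more compound is needed for the effect. Compound 1 `Cc1cc(C(=O)N2CCCCc3ccccc32)cc(C)c1CNC(=O)Nc1c(F)cccc1F` gives 82 nM, compound 2 `Cc1cc(C(=O)N2CCCCc3ccccc32)ccc1CNC(=O)Nc1ccccc1F` gives 30 nM, and compound 3 `Cc1cc(C(=O)N2CCCCc3ccccc32)ccc1CNC(=O)Nc1ccccc1` gives 130 nM. Compound 3 thus carries the highest number of the three; its gap to compound 1 lies within the scatter, while the step of a 4.3-fold higher number from compound 2 to compound 3 (0.64 log units; beyond the scatter) lies beyond it.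

Compound 4 `COC(=O)CNC(=O)NCc1ccc(C(=O)N2CCCCc3ccccc32)cc1C` differs from compound 3 by (methoxycarbonyl)methyl in place of phenyl on an amide-type nitrogen. Among the compounds with values here, no measured step touches the urea nitrogen in this way; the only step on record, a 4.3-fold higher number from compound 2 to compound 3 (0.64 log units; beyond the scatter), concerns a substituent on the phenyl that now leaves, and it shows that this region of the molecule is sensitive to change. Replacing the whole phenyl with a chain is a larger alteration than removing one fluoro, so a further rise in the number is expected, estimated at a 4.6-fold higher number from compound 3 to compound 4 (0.66 log units; beyond the scatter). Compound 4 is therefore expected to give about 600 nM in this assay, with a likely range from 150 nM to 3000 nM.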

Compound 4, half-maximal effective concentration: 37 nM
Compound 4: middle estimate off by 16-fold (1.21 log units), on the high side; measured number below the stated range.
By their numbers in this assay, from the lowest: compounds 2 and 4 (each within the scatter of the next); then compounds 1 and 3 (each within the scatter of the next).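

In this assay, a ring on this amide-type nitrogen proves not to be required: (methoxycarbonyl)methyl in place of phenyl gives a 3.5-fold lower number from compound 3 to compound 4 (0.55 log units; beyond the scatter) and so improves on the unsubstituted phenyl. Set against the 2-fluorophenyl group, the same chain gives a 1.2-fold higher number from compound 2 to compound 4 (0.09 log units; within the scatter), which places the two groups level and shows that an aromatic ring and an open chain bearing an ester can serve equally well at this position. Nothing at hand explains why the chain performs as it does.

From the compounds shown here alone, it remains open whether the ester itself matters, or whether the corresponding carboxylic acid, a primary amide or a simple ethyl chain would serve as well. Also open, going by these compounds, is whether a longer chain, such as (2-(methoxycarbonyl)ethyl), would hold the number at this level in this assay or move it.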